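Aminothiazole acylguanidines: urea substituent variation

The source may hold more compounds than are shown below. What is called first, only, known or untested is meant among the compounds shown, and "the series" means these compounds.

Measured:
compound 1 `Cc1nc(N)sc1CCCN/C(N)=N/C(=O)NCc1ccco1` — 10.5 nM
compound 2 `Cc1nc(N)sc1CCCN/C(N)=N/C(=O)NCC(C)C1CCCCC1` — 39.8 nM

In an assay on membranes from Sf9 cells for displacement of a labelled ligand from histamine H2 receptor (Homo sapiens), read by scintillation counting, with a stated time of 60 min (a higher number here means a weaker inhibitor, a lower number a stronger inhibitor), compound 1 gives 10.5 nM, the lower of the two numbers. For the measured compounds named here, the single step known, a 3.8-fold higher number from compound 1 to compound 2 (0.58 log units; beyond the scatter), exchanges one saturated-chain substituent for another. Compound 3 `Cc1nc(N)sc1CCCN/C(N)=N/C(=O)Nc1ccccc1` differs from compound 1 by phenyl in place of (furan-2-yl)methyl on an amide-type nitrogen, which puts an aromatic ring directly on the amide-type nitrogen and removes the hydrogen-bond acceptor of the furan. Going by the values given here, no measured step covers an aryl group on that nitrogen, so the earlier step only loosely informs this one. A modest weakening is expected, a 2.4-fold higher number from compound 1 to compound 3 (0.38 log units; beyond the scatter), giving an estimated 25 nM for compound 3 in this assay, within 8 nM to 80 nM.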

Compound 3, inhibition constant: 3160 nM
Beside the measured number, compound 3's estimate is 130-fold (2.10 log units) below it, outside the stated range (above it).
By their numbers in this assay, from the lowest: compound 1; then compound 2; then compound 3.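

Phenyl in place of (furan-2-yl)methyl on the amide-type nitrogen gives a 300-fold higher number from compound 1 to compound 3 (2.48 log units; beyond the scatter) in this assay, far more than the earlier exchange on the saturated chain carbon (a 3.8-fold higher number from compound 1 to compound 2 (0.58 log units; beyond the scatter)). Compound 1 and compound 2 both keep a saturated chain carbon on this nitrogen, whereas compound 3 carries its aromatic ring directly on it, and the position is clearly not open to every change. Nothing on hand explains the size of this step.

The change replaces the ring and removes the chain carbon together, and the compounds shown do not separate the two. Benzyl, or furan-2-yl directly on the nitrogen, would separate them.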